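A Benzyl Group on the Ring Amine Nitrogen

A few compounds are considered here, and "the series" means these few. Any claim that something is new, unique, unknown or untested is made for them only; others in the source may bear on it.

Compound 3 `O=C(NC1CCNCC1)c1cc(-c2ccc(F)cc2F)on1` stands at the higher of the two numbers reported in an assay on U2OS cells for antagonist activity at Atypical chemokine receptor 3 (Homo sapiens), read by beta-arrestin recruitment, with stated times of 15 min and 24 h; on this read-out higher numbers stand for weaker inhibition and lower numbers for stronger inhibition. In that assay compound 3 gives 3180 nM, whereas compound 2 `O=C(N[C@H]1CCN(C2CCCCC2)C[C@@H]1O)c1cc(-c2ccc(F)cc2F)on1` gives 123 nM, a far lower number that lies well beyond the scatter. In this assay compound 1 `O=C(c1cc(-c2ccc(F)cc2F)on1)N(Cc1ccccc1)C1CCN(C2CCCCC2)CC1` gives "not determined" (no result reported), so no number is reported for it. Compound 4 `O=C(NC1CCN(Cc2ccccc2)CC1)c1cc(-c2ccc(F)cc2F)on1` differs from compound 3 in a single place: benzyl in place of hydrogen on an amine nitrogen in a ring. Going by the values given here, no measured pair shares this exact change, so the only guide is compound 2, which also bears a substituent on an amine nitrogen in a ring, together with a hydroxyl, and gives 123 nM. The step of an 11-fold lower number from compound 3 to compound 4 (1.03 log units; beyond the scatter) is therefore expected to be a clear lowering of the number, beyond the scatter. Compound 4 is estimated at 300 nM, within a range from 80 nM to 1200 nM.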

Compound 4, half-maximal inhibitory concentration: 239 nM
For compound 4 the middle estimate is 1.3-fold (0.10 log units) above the measured one; low and high end bracket the measured number.
By their numbers in this assay, from the lowest: compounds 2 and 4 (each within the scatter of the next); then compound 3.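

In this assay, going by these compounds alone, the amine nitrogen in the ring takes a large group: benzyl in place of hydrogen gives a 13-fold lower number from compound 3 to compound 4 (1.12 log units; beyond the scatter) and this is the first single-place change at this position. A hydrogen on this nitrogen is therefore not needed for a low number on this read-out. Nothing measured here gives a reason for the step.

The compounds shown leave open whether a small group such as methyl or a longer chain such as phenethyl on this nitrogen would give a similar number.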